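A few compounds are considered here, and "the series" means these few. Any claim that something is new, unique, unknown or untested is made for them only; others in the source may bear on it.

Measured compounds in a functional assay on RKO cells (Homo sapiens) for antiproliferative activity, read by MTT assay, with a stated time of 5 days; on this read-out lower numbers stand for stronger inhibition and higher numbers for weaker inhibition:
- compound 1 `COc1cc[nH]c1/C=C1\C(=O)Nc2ccc([N+](=O)[O-])cc21` gives 692 nM
- compound 2 `COc1cc[nH]c1/C=C1\C(=O)Nc2ccc([N+](=O)[O-])c(N3CCC(O)CC3)c21` gives < 10 nM; this value is a limit of the assay
- compound 3 `COc1cc[nH]c1/C=C1\C(=O)Nc2ccc([N+](=O)[O-])c(N3CC[C@@H](N)C3)c21` gives < 10 nM; this value is a limit of the assay

Compound 3 therefore stands at the limit of this assay, the same limit at which compound 2 sits (the limit of < 10 nM in this assay, at which 2 of the 3 values shown sit). Against compound 1 the step is an at least 69-fold lower number from compound 1 to compound 3 (1.84 log units; beyond the scatter); the parallel step an at least 69-fold lower number from compound 1 to compound 2 (1.84 log units; beyond the scatter) runs to the same limit. The step that the two limits leave unreadable from compound 2 to compound 3, so the two substituted compounds cannot be ordered.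

Compound 4 `COc1cc[nH]c1/C=C1\C(=O)Nc2ccc([N+](=O)[O-])c(N[C@H]3CC[C@H](N)C3)c21` carries the change (3-aminocyclopentyl)amino in place of 3-aminopyrrolidin-1-yl on an aromatic carbon, placed ortho to a fused ring and ortho to a nitro group, meta to a fused ring. Both measured steps at this position, from compound 1 to compound 2 and from compound 1 to compound 3, were large drops in number, whichever amine ring was introduced; a third amine-bearing five-membered ring is expected to behave similarly, though its effect beyond the limit is not readable. The step is estimated as an at least 1.2-fold higher number from compound 3 to compound 4 (0.07 log units; that floor lies within the scatter), that is, none beyond the scatter in either direction. Compound 4 is estimated at 12 nM in this assay, with a range from 3 nM to 50 nM.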

Compound 4, half-maximal inhibitory concentration: < 15 nM
Compound 4: no number, only a limit (the forecaster's own chance of this, stated with the estimate: 40%); the middle value lies beyond the limit too.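

In this assay, the entry of (3-aminocyclopentyl)amino on the aromatic carbon ortho to a nitro group gives an at least 46-fold lower number from compound 1 to compound 4 (1.66 log units; beyond the scatter), so the large drop at this position also holds for a five-membered non-aromatic ring of carbon only, not just for the rings with a hetero atom in compound 2 and compound 3. The value of compound 4 is itself a limit of the assay, and a different one from that of the other two substituted compounds: the limit of < 15 nM in this assay, at which 1 of the 4 values shown sits. The steps among compound 2, compound 3 and compound 4 cannot be read, so the three substituted compounds cannot be ordered, and neither the ring type nor the added stereocentre can be credited with any gain or loss.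

On these data alone, what remains open is how far the drop depends on the terminal amine, which a hydroxyl on the cyclopentyl ring, a carboxylic acid or a plain dimethylamino group at the same place would test. Also open, as far as these compounds go, is whether the other stereoisomers of (3-aminocyclopentyl)amino hold the same level.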